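This account rests on a few compounds, and the source may have more. Where it says the series, first, only, none or still open, it means among the compounds named here.

Measured compounds:
Compound 1 `CCOCCOC(=O)Nc1cc2nc(C3CCCCC3)[nH]c2cc1N(C)C` gives > 100 ug/mL in an ADME assay on Vero cells (Chlorocebus sabaeus) for cytotoxicity, read by resazurin assay, with a stated time of 3 days (a higher number here means a weaker inhibitor, a lower number a stronger inhibitor), which is a limit of the assay rather than a number.
Compound 2 `Cc1ccc(C(=O)Nc2cc3nc(C4CCCCC4)[nH]c3cc2N2CCCC2)cc1` gives > 100 ug/mL in this assay, again a limit of the assay.

On the numbers shown, compound 1 cannot be placed more precisely than this: both values recorded in this assay sit at the limit of > 100 ug/mL in this assay, at which 2 of the 2 values shown sit, so no ordering between compound 1 and compound 2 can be read from them.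

Compound 3 `CN(C)c1cc2[nH]c(C3CCCCC3)nc2cc1NC(=O)c1ccc(C(C)(C)C)cc1` is drawn from compound 1 by a single change: 4-(tert-butyl)phenyl in place of 2-ethoxyethoxy on a carbonyl carbon. Among the measured compounds shown here, no step between measured compounds exists to gauge it against. With both measured compounds resting at the limit, the step from compound 1 is expected to be none beyond the scatter, and compound 3 is expected most likely to return a limit as well.

Compound 3 is therefore estimated at 120 ug/mL in this assay, within a range from 40 ug/mL to 400 ug/mL. The step implied by this estimate, a step that the limit leaves unreadable from compound 1 to compound 3, is expected to be none beyond the scatter.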

Compound 3, half-maximal inhibitory concentration: > 100 ug/mL
Compound 3: only a limit was reported (the forecaster's own chance of this, stated with the estimate: 80%); the middle value lies beyond the limit too.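

No step from compound 1 to compound 3 can be read in this assay, since both results are limits rather than numbers: the limit of > 100 ug/mL in this assay, at which 3 of the 3 values shown sit.

The compounds shown leave open whether they differ at all in this read-out, and at what concentration, if any, cytotoxicity would appear.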